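Anilino swap on the triazolylmethylthio pyrimidine series

The compounds below may be only part of what the source reports. "The series", "measured", "known", "first", "only" and "open" are said of these compounds alone.

Of the compounds shown here, two have numbers so far. Compound 1 `C#CCSc1nc(Nc2ccc(OC)cc2)c(C#N)c(-c2ccccc2)n1` gives 23200 nM in a functional assay on ECa-109 cells (Homo sapiens) for inhibition, read by MTT assay, with a stated time of 72 h (on this read-out lower numbers stand for stronger inhibition and higher numbers for weaker inhibition), while compound 2 `COc1ccc(Nc2nc(SCc3cn(Cc4ccccc4Cl)nn3)nc(-c3ccccc3)c2C#N)cc1` gives 7960 nM in this assay. Compound 2 thus holds the lowest of the two numbers, with compound 1 standing a good way higher, a gap that lies beyond the usual scatter. For the measured compounds named here, no other pair with a single point of difference is available, so the effect of changing one group at a time has not been isolated in this set.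

Compound 3 `N#Cc1c(Nc2ccccc2Cl)nc(SCc2cn(Cc3ccccc3Cl)nn2)nc1-c1ccccc1` is the next member to be run in this assay. It differs from compound 2 in one place: 2-chlorophenyl in place of 4-methoxyphenyl on a nitrogen on an aromatic ring. Going by the values given here, nothing among the measured compounds speaks to this kind of exchange, so no direction can be read from the data. The step of a 1.1-fold higher number from compound 2 to compound 3 (0.05 log units; within the scatter) is therefore expected to stay within the scatter, with a wide margin either way. In this assay compound 3 is estimated at 9000 nM, with the range running from 3000 nM to 30000 nM.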

Compound 3, half-maximal inhibitory concentration: 28500 nM
Beside the measured number, compound 3's estimate is 3.2-fold (0.50 log units) below it; the measured number falls inside the stated range.
By their numbers in this assay, from the lowest: compound 2; then compounds 1 and 3 (each within the scatter of the next).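

In this assay, for the compounds shown here, the exchange of (4-methoxyphenyl)amino for (2-chlorophenyl)amino gives a 3.6-fold higher number from compound 2 to compound 3 (0.55 log units; beyond the scatter) and is the first step that isolates a single place. The group on this nitrogen therefore matters to the read-out, and of the two aryl groups tested here, 4-methoxyphenyl goes with the stronger inhibition. No measurement at hand accounts for the step.

The 2-chlorophenyl and 4-methoxyphenyl groups differ in both substituent and substitution pattern, so this one step cannot separate the effect of losing the methoxy group from that of introducing the chlorine or of moving the substituent. Plain phenyl on the same nitrogen would give a reference for both groups, and a cyclohexyl group there would test whether an aromatic ring is needed at this position at all.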